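Amide-to-urea exchange on the aminothienopyrimidine piperazines

The compounds below may be only part of what the source reports. "The series", "measured", "known", "first", "only" and "open" are said of these compounds alone.

Measured so far in a functional assay on cells (Lymphocyte); on this read-out lower numbers stand for stronger inhibition and higher numbers for weaker inhibition:
- compound 1, `O=C(COc1ccc(Cl)cc1)N1CCN(c2ncnc3sc(F)cc23)CC1`, gives 6350 nM.
- compound 2, `CCOC(=O)c1nc(N2CCN(C(=O)COc3ccc(Cl)cc3)CC2)c2cc(F)sc2n1`, reaches only the assay limit, > 10000 nM.
- compound 3, `Nc1nc(N2CCN(C(=O)CCc3ccccc3)CC2)c2cc(F)sc2n1`, gives 6990 nM.

Compound 3 sits close to compound 1; the two numbers lie within the usual scatter of each other, so no order between them can be read. Within the data shown here, the only other value, that of compound 2, is the limit described in the limit of > 10000 nM in this assay, at which 1 of the 3 values shown sits, and gives no number to rank against.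

Among the measured compounds shown here, only one step among the measured compounds is defined: an at least 1.5-fold higher number from compound 1 to compound 2 (0.19 log units; that floor lies within the scatter). It changes a substituent on an aromatic carbon of the shared core and says nothing about the acyl side of the piperazine.

Compound 4, `Cc1cccc(NC(=O)N2CCN(c3nc(N)nc4sc(F)cc34)CC2)c1`, is not yet measured. It differs from compound 3 as follows: (3-methylphenyl)amino in place of phenethyl on a carbonyl carbon. For the measured compounds named here, no measured step touches the carbonyl substituent, so nothing here points to a step beyond the scatter in either direction. The expectation for compound 4 therefore stays near compound 3: an estimated 5500 nM, with a range from 1500 nM to 15000 nM, which corresponds to an estimated 1.3-fold lower number from compound 3 to compound 4 (0.10 log units; within the scatter).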

Compound 4, half-maximal inhibitory concentration: 2800 nM
Beside the measured number, compound 4's estimate is 2.0-fold (0.29 log units) above it; the measured number falls inside the stated range.
By their numbers in this assay, from the lowest: compound 4; then compounds 1 and 3 (each within the scatter of the next). At a limit, above all of these: compound 2.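

In this assay, among these compounds, (3-methylphenyl)amino in place of phenethyl on the carbonyl carbon gives a 2.5-fold lower number from compound 3 to compound 4 (0.40 log units; beyond the scatter), the first step with a readable direction. Among the compounds shown here, the carbonyl substituent is therefore a place where the read-out moves, which the only earlier step, made on an aromatic carbon of the shared core, could not show. Both groups carry one six-membered aromatic ring of carbon only, so the exchange brings in a nitrogen and a hydrogen-bond donor while keeping the ring, but nothing shown ties the step to either of these or to the methyl, and no available evidence bears on its cause.

Open, from the compounds shown here alone, is how much of the step belongs to the amino hydrogen and how much to the methyl; a plain phenylamino group and a methyl(3-methylphenyl)amino group on the same carbonyl carbon would separate the two. Also open, going by these compounds, is whether the exchange carries over to the core of compound 1, which has no amino group.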